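A few compounds are considered here, and "the series" means these few. Any claim that something is new, unique, unknown or untested is made for them only; others in the source may bear on it.

The read-out throughout these notes is an ADME assay on microsomes from liver (Homo sapiens) for metabolic stability, read by mass spectrometry, using NADPH, with a stated time of 60 min; on this read-out lower numbers stand for a less stable compound and higher numbers for a more stable compound. Compound 1 (`O=C(CNC1CC1c1cc(F)cc(F)c1OCc1cccnc1F)N1CCC2(CCNC2)CC1`) is drawn without configuration at its two saturated ring carbons and gives 44% there. Compound 2 (`O=C(CN[C@H]1C[C@@H]1c1cc(F)cc(F)c1OCc1cccnc1F)N1CCC2(CCNC2)CC1`) has the same atoms and bonds with both centres defined and gives 38% there, which lies within the scatter of compound 1, so no order can be read between the two.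

Compound 3 (`O=C(CN[C@@H]1C[C@H]1c1cc(F)cc(F)c1OCc1cccnc1F)N1CCC2(CCNC2)CC1`) comes next, and the change is this (the two compounds have the same atoms and bonds and differ only in configuration as drawn: 2 of 2 stereo elements differ (all stereocentres are inverted: mirror images); a stereocentre at a saturated ring carbon is drawn S in compound 2 and R in compound 3; a stereocentre at a saturated ring carbon is drawn R in compound 2 and S in compound 3): nothing leaves, nothing enters, and all stereocentres are inverted, making compound 3 the mirror image of compound 2. For the measured compounds named here, the one measured step bearing on this is a number 6 percentage points lower from compound 1 to compound 2 (within the scatter) and it concerns only the fact that one of compounds 1 and 2 is drawn with a defined configuration and the other without, at the place where they differ. Going by the values given here, no pair of defined mirror images has been measured yet, so this is a weak guide. Resting on a number 6 percentage points lower from compound 1 to compound 2 (within the scatter) as the only guide, no change beyond the scatter is expected in this assay for this inversion. The estimated size is a number 6 percentage points higher from compound 2 to compound 3 (within the scatter) for now. Compound 3 is expected at 44% with an estimated range from 28% to 60% on this read-out.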

Compound 3, percent of the compound remaining: 45%
For compound 3 the middle estimate is 1 percentage points below the measured one; the measured number falls inside the stated range.
By their numbers in this assay, from the lowest: compounds 2, 1 and 3 (each within the scatter of the next).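

For the compounds shown here, compounds 2 and 3 form the first pair of defined mirror images in this assay, and full inversion of the two stereocentres stays within the scatter (a number 7 percentage points higher from compound 2 to compound 3 (within the scatter)), so no order can be read between them. Compound 1, drawn without configuration at the same two saturated ring carbons, also stays within the scatter of compound 3 (a number 1 percentage points higher from compound 1 to compound 3 (within the scatter)), which adds to its earlier step to compound 2. At this position, then, the drawn configuration of this mirror-image pair leaves no separation beyond the scatter on this read-out, a finding limited to the three compounds and resting on this comparison: (the fact that compounds 2 and 3 differ only in the configuration as drawn).

What remains open is whether the other relative arrangement of the two stereocentres, which is absent from the compounds shown, would read the same way. Going by these compounds, it is also open whether the same indifference to inversion would hold with a different group on the shared core, such as a carboxylic acid or a longer chain on the amine nitrogen.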